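This account rests on a few compounds, and the source may have more. Where it says the series, first, only, none or still open, it means among the compounds named here.

Two compounds of this series have numbers in an ADME assay on MT4 cells (Homo sapiens) for cytotoxicity, read by MTT assay; a higher number here means that more compound is tolerated, a lower number that less compound is tolerated. Compound 1 (`O=C1c2ccccc2C(=O)N1CCOC(=S)N(C(=O)c1c(Cl)cccc1Cl)c1ccc(Cl)cc1`) gives 20000 nM, and compound 2 (`O=C1c2ccccc2C(=O)N1CCOC(=S)N(C(=O)c1ccc([N+](=O)[O-])cc1Cl)c1ccc(Cl)cc1`) gives 19000 nM. Going by the values given here, these two values lie within the scatter of each other, so compound 2 stands level with the only other measured compound. Compound 3 (`O=C1c2ccccc2C(=O)N1CCOC(=S)N(C(=O)c1ccc(Cl)c([N+](=O)[O-])c1)c1ccc(Cl)cc1`) has not yet been measured in this assay. It keeps the shared core of compound 2 and differs only on a carbonyl carbon, where 4-chloro-3-nitrophenyl stands in place of 2-chloro-4-nitrophenyl: 4-chloro-3-nitrophenyl in place of 2-chloro-4-nitrophenyl on a carbonyl carbon. Among the compounds with values here, one measured step bears on this change, since it also swaps the group on that carbonyl carbon: a 1.1-fold lower number from compound 1 to compound 2 (0.02 log units; within the scatter). That step stays within the scatter, but it is a single step and involves a different pair of groups, so it offers only thin support. On that basis, no step beyond the scatter is expected. The expected step is no change at the digits printed from compound 2 to compound 3 (within the scatter). For compound 3, the half-maximal cytotoxic concentration is estimated at 19000 nM, with an expected range from 9000 nM to 40000 nM.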

Compound 3, half-maximal cytotoxic concentration: 48000 nM
Compound 3: middle estimate off by 2.5-fold (0.40 log units), on the low side; the measured number lies above the stated range.
By their numbers in this assay, from the lowest: compounds 2 and 1 (each within the scatter of the next); then compound 3.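

In this assay, the group on this carbonyl carbon proves able to shift the number beyond the scatter: with 4-chloro-3-nitrophenyl in place of 2-chloro-4-nitrophenyl, the result is a 2.5-fold higher number from compound 2 to compound 3 (0.40 log units; beyond the scatter), even though the two groups hold the same atoms, joined differently. The same group in place of 2,6-dichlorophenyl gives a 2.4-fold higher number from compound 1 to compound 3 (0.38 log units; beyond the scatter), so both steps to 4-chloro-3-nitrophenyl run in the same direction, whereas the earlier swap at this position, a 1.1-fold lower number from compound 1 to compound 2 (0.02 log units; within the scatter), stayed within the scatter. No measurement is available that would explain how this rearrangement of the same atoms leads to a different number.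

The three compounds leave open whether the higher number of compound 3 follows from the new arrangement of the chlorine, of the nitro group, or of the two together, since the step from compound 2 changes both at once. They also leave open how the number would move if an amine or a carboxylic acid stood on that phenyl ring in place of the nitro group, and whether any such change would carry over to other groups on the shared core.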